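This account rests on a few compounds, and the source may have more. Where it says the series, first, only, none or still open, it means among the compounds named here.

Compound 1 `C=C[C@@](C)(/C=C/c1ccc(OCc2ccccc2)cc1)CCC=C(C)C` and compound 2 `CCOC(=O)/C(C)=C/c1cc(/C=C/[C@](C)(/C=C/c2ccc(OC)cc2)CCC=C(C)C)ccc1O` were both tested in a functional assay on NALM-6 cells (Homo sapiens) for cytotoxicity, with a stated time of 72 h; on this read-out lower numbers stand for an effect already at smaller amounts and higher numbers for an effect only at larger amounts of compound. In this assay compound 1 gives > 43400 nM, a limit of the assay rather than a number. Compound 2 likewise gives > 43400 nM, again only a limit. Compound 1 therefore sits where the measured values end, because of the limit of > 43400 nM in this assay, at which 2 of the 2 values shown sit. Compound 3 `C=C[C@@](C)(/C=C/c1ccc(-c2ccc(Cl)c(Cl)c2)cc1)CCC=C(C)C` differs from compound 1 by 3,4-dichlorophenyl in place of benzyloxy on an aromatic carbon. Going by the values given here, no measured step between two compounds is available to guide the size of this change. The step from compound 1 to compound 3 is expected to be an at least 1.0-fold lower number from compound 1 to compound 3 (0.03 log units; that floor lies within the scatter), nothing beyond the scatter. Compound 3 is estimated at 40000 nM in this assay, within a range from 12000 nM to 100000 nM.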

Compound 3, half-maximal effective concentration: > 43400 nM
Compound 3 gave a limit, no number (the forecaster's own chance of this, stated with the estimate: 65%); middle value at least 1.0-fold (0.03 log units) away from the limit.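

Compound 1 and compound 3 both give only a limit in this assay, and no step can be read between them. The compounds shown leave open whether 3,4-dichlorophenyl in place of benzyloxy changes the read-out at all.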